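The compounds below may be only part of what the source reports. "The series", "measured", "known", "first", "only" and "open" are said of these compounds alone.

- Compound 1 `CS(=O)(=O)N1C[C@H](C(=O)Nc2ccc(Cl)cc2)[C@@H](C(=O)Nc2ccc(-n3ccccc3=O)cc2F)C1`: 2.17
- Compound 2 `CC(C)N1C[C@H](C(=O)Nc2ccc(Cl)cc2)[C@@H](C(=O)Nc2ccc(-n3ccccc3=O)cc2F)C1`: "not determined" (no result reported)
- Compound 3 `O=C(Nc1ccc(Cl)cc1)[C@H]1CN(Cc2cccs2)C[C@@H]1C(=O)Nc1ccc(-n2ccccc2=O)cc1F`: "not determined" (no result reported)

For the measured compounds named here, in a physicochemical assay for lipophilicity, at pH 7.4 (a higher number here means a more lipophilic compound, a lower number a more polar compound), compound 1 gives 2.17, the only number in this small set. Compound 2 shows "not determined" (no result reported), and compound 3 likewise shows "not determined" (no result reported), so neither offers a comparison. Compound 4 `COc1ccc(NC(=O)[C@H]2CN(S(C)(=O)=O)C[C@@H]2C(=O)Nc2ccc(-n3ccccc3=O)cc2F)cc1F` keeps the core of compound 1 and has 3-fluoro-4-methoxyphenyl in place of 4-chlorophenyl on an amide-type nitrogen. Going by the values given here, no measured pair shows what such an exchange does in this assay, so the expectation rests on the structural change alone. A small downward move is expected, a number 0.22 log units lower from compound 1 to compound 4 (within the scatter), and it would not clearly exceed the usual scatter. The estimated value for compound 4 is 1.95, within an expected range of 1.55 to 2.35.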

Compound 4, distribution coefficient: 0.56
Compound 4: middle estimate off by 1.39 log units, on the high side; the measured number lies below the stated range.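

In this assay, for the compounds shown here, the exchange of 4-chlorophenyl for 3-fluoro-4-methoxyphenyl on an amide-type nitrogen gives a number 1.61 log units lower from compound 1 to compound 4 (beyond the scatter) and so supplies the first measured step in this set. It shows that a change at this one place, with the rest of the structure held constant, can move the read-out well beyond the scatter. Nothing available accounts for the size of this step. As far as these compounds go, it remains open which part of the exchange carries the step, and 4-methoxyphenyl or 3-fluorophenyl alone would separate the two. From the compounds shown here alone, how a pyridyl group or a longer chain would read at this place also remains open.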